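Working notes: aryl exchange on compound 3

The compounds below may be only part of what the source reports. "The series", "measured", "known", "first", "only" and "open" are said of these compounds alone.

Values from a functional assay on MCF7 cells (Homo sapiens) for inhibition, read by MTT assay, with a stated time of 48 h, tested at 10 uM (on this read-out lower numbers stand for less inhibition of growth and higher numbers for more inhibition of growth at the one concentration tested), are as follows

compound 1 `Cc1cc(=O)c2c(O)c(CN3CCCC3CO)c(O)c([C@H]3CCN(C)C[C@H]3O)c2o1` gives 22%
compound 2 `Cc1cc(=O)c2c(O)c(CN3CC(O)CC3C(=O)O)c(O)c([C@H]3CCN(C)C[C@H]3O)c2o1` gives 25%
compound 3 `Cc1oc2c([C@H]3CCN(C)C[C@H]3O)c(O)cc(O)c2c(=O)c1C(O)c1cccc(Cl)c1` gives 5%

Compound 3 stands lowest of the three, with its gaps to compound 1 and compound 2 beyond the scatter. Compound 4 `Cc1oc2c([C@H]3CCN(C)C[C@H]3O)c(O)cc(O)c2c(=O)c1C(O)c1cc(F)cc(F)c1` differs from it by 3,5-difluorophenyl in place of 3-chlorophenyl on a saturated chain carbon bound to an aromatic carbon and an oxygen on a saturated carbon (3,5-difluorophenyl in place of 3-chlorophenyl). Going by the values given here, the only measured step, a number 3 percentage points higher from compound 1 to compound 2 (within the scatter), lies at another place on the molecule. Among the compounds with values here, no measured step covers this aryl exchange, so no step beyond the scatter is expected in this assay, starting from compound 3 at 5% here. The estimated change is a number 4 percentage points higher from compound 3 to compound 4 (within the scatter) in this series. Compound 4 is expected at 9% (estimated range 0% to 22%).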

Compound 4, percent growth inhibition at one concentration: 25%
Estimate against measurement, compound 4: 16 percentage points below; the whole stated range lies below it.
By their numbers in this assay, from the lowest: compound 3; then compounds 1, 2 and 4 (each within the scatter of the next).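

In this assay, the aryl group on a saturated chain carbon bound to an aromatic carbon and an oxygen on a saturated carbon proves to matter: 3,5-difluorophenyl in place of 3-chlorophenyl gives a number 20 percentage points higher from compound 3 to compound 4 (beyond the scatter). The one earlier step lay at another place on the molecule and stayed within the scatter, so this is the first change in the series shown to move the number beyond it. Nothing available explains this step.

Open, on these data alone, is whether 3-fluorophenyl or 3,5-dichlorophenyl at this place would give a similar number. Also open, as far as these compounds go, is how an aliphatic amine in place of the aryl group would read out.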